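Halogen swap on the amine-bound aryl group: compound 4

This account rests on a few compounds, and the source may have more. Where it says the series, first, only, none or still open, it means among the compounds named here.

Three compounds share one core and differ only in the group on the saturated chain carbon bound to the amine nitrogen in the ring. Compound 1 `CC(C)(C)c1cc(/C=C/C(=O)NCCC2CCN(Cc3ccccc3)CC2)cc(C(C)(C)C)c1O` gives 8500 nM in an assay on isolated protein for inhibition of Amine oxidase [flavin-containing] B (Homo sapiens), read by fluorescence, with stated times of 15 min and 20 min; on this read-out lower numbers stand for stronger inhibition and higher numbers for weaker inhibition. Compound 2 `COc1ccc(CN2CCC(CCNC(=O)/C=C/c3cc(C(C)(C)C)c(O)c(C(C)(C)C)c3)CC2)cc1` gives 6700 nM in this assay, and compound 3 `CC(C)(C)c1cc(/C=C/C(=O)NCCC2CCN(Cc3ccccc3Cl)CC2)cc(C(C)(C)C)c1O` gives 9800 nM in this assay. Compound 3 carries the highest of the three numbers shown, yet its separation from the others is small: a 1.2-fold higher number from compound 1 to compound 3 (0.06 log units; within the scatter) and a 1.5-fold higher number from compound 2 to compound 3 (0.17 log units; within the scatter), both within the scatter, and the remaining pair likewise shows a 1.3-fold lower number from compound 1 to compound 2 (0.10 log units; within the scatter).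

Compound 4 `CC(C)(C)c1cc(/C=C/C(=O)NCCC2CCN(Cc3ccc(Br)cc3)CC2)cc(C(C)(C)C)c1O` is the next member, not yet measured in this assay. The change from compound 3 is 4-bromophenyl in place of 2-chlorophenyl on a saturated chain carbon bound to an amine nitrogen in a ring. Going by the values given here, the steps that bear on it are those that also alter this aryl group: a 1.2-fold higher number from compound 1 to compound 3 (0.06 log units; within the scatter), a 1.5-fold higher number from compound 2 to compound 3 (0.17 log units; within the scatter) and a 1.3-fold lower number from compound 1 to compound 2 (0.10 log units; within the scatter). None of them moved the number beyond the scatter, whether a halogen or a methoxy was added, or one substituted phenyl replaced another. No step beyond the scatter is therefore expected in this assay for compound 4 either, in either direction. The expected step is a 1.1-fold lower number from compound 3 to compound 4 (0.04 log units; within the scatter). Compound 4 is estimated at 9000 nM in this assay, with a range from 4500 nM to 18000 nM.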

Compound 4, half-maximal inhibitory concentration: 13200 nM
Compound 4: the middle estimate sits 1.5-fold (0.17 log units) below what was measured; low and high end bracket the measured number.
By their numbers in this assay, from the lowest: compounds 2, 1, 3 and 4 (each within the scatter of the next).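

In this assay, the change to 4-bromophenyl on a saturated chain carbon bound to an amine nitrogen in a ring gives only a 1.3-fold higher number from compound 3 to compound 4 (0.13 log units; within the scatter), so the earlier flat picture now extends to a bromo-bearing aryl group. The comparisons with the unsubstituted phenyl group, a 1.6-fold higher number from compound 1 to compound 4 (0.19 log units; within the scatter), and with 4-methoxyphenyl, a 2.0-fold higher number from compound 2 to compound 4 (0.29 log units; within the scatter), the largest step among the four compounds, are also printed as within the scatter, so hydrogen, chloro, bromo and methoxy on this aryl group give no order that can be read. No supporting data bear on why this aryl group changes the number so little.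

The step from 2-chlorophenyl to 4-bromophenyl changes the halogen and its ring location together, so 4-chlorophenyl and 2-bromophenyl would be needed to separate the two changes. Also open, from the compounds shown here alone, is whether any group at this place can move the number beyond the scatter, such as a carboxylic acid or an amino group on the phenyl ring, a pyridyl group in place of phenyl, or a phenethyl group in place of benzyl.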